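A Methyl-to-Ethyl Step Starting from Compound 3

The source may report more compounds than this note shows. Statements on the series, on what has been measured and on what is new or still open speak of the compounds shown alone.

Measured in a functional assay on IMR-90 cells for antagonist activity at B1 bradykinin receptor (Homo sapiens), read by calcium flux; a lower number here means a stronger inhibitor, a higher number a weaker inhibitor:
compound 1, `Cc1nc(-c2c(F)cc(Cl)cc2-c2cnc(CNC(=O)N(C)O)c(F)c2)no1`, gives 17 nM
compound 2, `Cc1nc(-c2c(F)cc(Cl)cc2-c2ccc(CNC(=O)N(C)O)c(F)c2)no1`, gives 32 nM
compound 3, `CN(O)C(=O)NCc1ncc(-c2cc(Cl)cc(F)c2-c2nnn(C)n2)cc1F`, gives 17 nM

Compound 3 stands level with compound 1, and these two share the lowest number; compound 2 shows a higher number, but that gap lies within the scatter, so no order among the three can be read. Among the compounds with values here, the only single-point step, no change at the digits printed from compound 1 to compound 3 (within the scatter), swaps one ring for another and says nothing about the part that now changes.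

Compound 4, `CCN(O)C(=O)NCc1ncc(-c2cc(Cl)cc(F)c2-c2nnn(C)n2)cc1F`, differs from compound 3 by methyl in place of hydrogen on a saturated chain carbon bound to an amide-type nitrogen. Within the data shown here, no measured step touches this position, so the expectation rests on the change itself being small: the step from compound 3 to compound 4 is expected to be a 1.3-fold higher number from compound 3 to compound 4 (0.11 log units; within the scatter), nothing beyond the scatter. Compound 4 is therefore estimated at 22 nM, between 8 nM and 60 nM.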

Compound 4, half-maximal inhibitory concentration: 4.6 nM
Compound 4: middle estimate off by 4.8-fold (0.68 log units), on the high side; the measured number lies below the stated range.
By their numbers in this assay, from the lowest: compound 4; then compounds 1, 3 and 2 (each within the scatter of the next).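

Within the data shown here, the change from hydroxy(methyl)amino to ethyl(hydroxy)amino gives the first measured step at this position, and in this assay it is a modest gain in strength (a 3.7-fold lower number from compound 3 to compound 4 (0.57 log units; beyond the scatter)). So this position responds to a single added methyl, whereas the earlier ring swap left the number in place. No measurement at hand explains this step. A single step cannot show whether a longer chain such as propyl, or a branched one such as isopropyl, would lower the number further. From the compounds shown here alone, whether ethyl would act the same way on the core of compound 1 also stays open.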